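Working notes: from compound 3 to compound 4

The source may hold more compounds than are shown below. What is called first, only, known or untested is meant among the compounds shown, and "the series" means these compounds.

Measured so far in a functional assay on the whole organism with Rattus norvegicus as the target, with a stated time of 4 h, at a dose of 40 mg/kg by the intraperitoneal route; on this read-out higher numbers stand for more inhibition at the one dose given (going by the name of the read-out) and lower numbers for less inhibition:
compound 1 `CC(=O)c1c(C)nc2c(OCc3ccccc3)cccn12` — 57%
compound 2 `CCSCc1c(C)nc2c(OCc3ccccc3)cccn12` — 36%
compound 3 `Cc1nc2c(OCc3ccccc3)cccn2c1CS(C)(=O)=O` — 61%

Going by the values given here, compound 3 has the highest of the three numbers in this assay ; its gap to compound 1 lies within the scatter, and only the step of a number 25 percentage points higher from compound 2 to compound 3 (beyond the scatter) stands beyond it. Compound 4 `Cc1nc2c(OCc3ccccc3)cccn2c1COC(=O)C(C)(C)C` differs from compound 3 by ((tert-butyl)carbonyl)oxy in place of methylsulfonyl on a saturated chain carbon bound to an aromatic carbon.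

Steps at the same place: a number 4 percentage points higher from compound 1 to compound 3 (within the scatter) and a number 25 percentage points higher from compound 2 to compound 3 (beyond the scatter). Among the compounds with values here, three different groups on that chain carbon give numbers spread over a modest range, and no measured step introduces an oxygen-linked group there, so the direction of the new step is uncertain. The step is expected to be a number 16 percentage points lower from compound 3 to compound 4 (beyond the scatter). Compound 4 is estimated at 45%, with a range from 22% to 66%.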

Compound 4, a percentage reported as inhibition, in the whole organism at one dose (the size of the read-out at that dose, not a potency): 48%
Estimate against measurement, compound 4: 3 percentage points below; low and high end bracket the measured number.
By their numbers in this assay, from the lowest: compound 2; then compounds 4, 1 and 3 (each within the scatter of the next, the first and the last beyond it).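

In this assay, going by these compounds alone, the first oxygen-linked group on this saturated chain carbon, ((tert-butyl)carbonyl)oxy, places compound 4 between the two sulfur-bearing compounds, with both gaps beyond the scatter (a number 13 percentage points lower from compound 3 to compound 4 (beyond the scatter); a number 12 percentage points higher from compound 2 to compound 4 (beyond the scatter)). Replacing acetyl with (((tert-butyl)carbonyl)oxy)methyl on the aromatic carbon leaves no resolved difference (a number 9 percentage points lower from compound 1 to compound 4 (within the scatter)). Nothing available accounts for these differences.

As far as these compounds go, a hydroxyl or an amine on that chain carbon remains open. So does a smaller acyl group in place of the tert-butyl part of the new group.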